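Phenyl for thiophen-2-yl on a weakly active pyridinone core

A few compounds are considered here, and "the series" means these few. Any claim that something is new, unique, unknown or untested is made for them only; others in the source may bear on it.

The measured compounds are:
compound 1, `COc1ccc(-c2cc(-c3cccn3C)c(C#N)c(=O)[nH]2)cc1OC`, > 100000 nM
compound 2, `COc1ccc(-c2cc(-c3cccn3C)c(C#N)c(N)n2)cc1OC`, 93300 nM
compound 3, `Cn1cccc1-c1cc(-c2cccs2)[nH]c(=O)c1C#N`, > 100000 nM

Compound 3 stands at a limit of the assay in a functional assay on MCF7 cells (Homo sapiens) for inhibition, read by sulforhodamine B assay, with a stated time of 48 h; on this read-out lower numbers stand for stronger inhibition of growth and higher numbers for weaker inhibition of growth: its value of > 100000 nM is a limit, not a number. One further value shown, that of compound 1, is also a limit. Within the data shown here, compound 2 is the only compound of the three with a numeric value, and it gives 93300 nM in this assay. Two of the three values thus rest at the limit (the limit of > 100000 nM in this assay, at which 2 of the 3 values shown sit).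

Compound 4, `Cn1cccc1-c1cc(-c2ccccc2)[nH]c(=O)c1C#N`, has not yet been measured. It differs from compound 3 in one place: phenyl in place of thiophen-2-yl on an aromatic carbon. Among the measured compounds shown here, nothing among the measured compounds shows how this exchange of one aromatic ring for another bears on growth inhibition, so no step beyond the scatter is expected in this assay in either direction. Compound 4 is therefore expected to remain near the limit, with an estimated value of 120000 nM, in a range from 30000 nM to 500000 nM. The estimated step that the limit leaves unreadable from compound 3 to compound 4 is expected to lie within the scatter.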

Compound 4, concentration for 50% growth inhibition: > 100000 nM
Compound 4 ended at the assay's limit; the forecaster's own chance of this, stated with the estimate: 75%; the middle value is on the limit's open side.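

Compound 3 and compound 4 both rest at a limit in this assay, and no step between them can be read: the limit of > 100000 nM in this assay, at which 3 of the 4 values shown sit.

The compounds shown leave open whether phenyl in place of thiophen-2-yl changes growth inhibition at all, in either direction.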